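Methoxy added to a benzyl ring on an inactive series

This account rests on a few compounds, and the source may have more. Where it says the series, first, only, none or still open, it means among the compounds named here.

Three compounds sharing a core were tested in a functional assay on AGS cells (Homo sapiens) for antiproliferative activity, read by MTT assay, with a stated time of 48 h; on this read-out higher numbers stand for weaker inhibition of growth and lower numbers for stronger inhibition of growth. Compound 1 `COc1ccc(N(C)c2ncnc3c2ncn3Cc2cc(OC)cc(OC)c2)cc1` gives only a limit of the assay, > 100000 nM. Compound 2 `COc1ccc(N(C)c2ncnc3c2ncn3Cc2cc(OC)c(OC)c(OC)c2)cc1` likewise reaches only the limit, > 100000 nM. Compound 3 `COc1ccc(Cn2cnc3c(N(C)c4ccc(OC)cc4)nc(Cl)nc32)cc1` again gives a limit, > 100000 nM. The change from compound 1 to compound 2 is methoxy in place of hydrogen on an aromatic carbon, and it produced a step that the two limits leave unreadable from compound 1 to compound 2 because of the limit of > 100000 nM in this assay, at which 3 of the 3 values shown sit. The difference between the cores of compound 1 and compound 3 is not broken down here.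

Compound 4 `COc1ccc(N(C)c2nc(Cl)nc3c2ncn3Cc2ccc(OC)c(OC)c2)cc1` has not yet been measured. It differs from compound 3 by methoxy in place of hydrogen on an aromatic carbon, the same kind of change as that between compound 1 and compound 2, though here the place is ortho to a methoxy group and meta to a large group rather than ortho to two methoxy groups and para to a large group. Since compound 3 sits at the limit, > 100000 nM, the step expected for compound 4 is estimated as a step that the limit leaves unreadable from compound 3 to compound 4. Compound 4 is therefore expected to show roughly 150000 nM in this assay, most likely reported again only as a limit.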

Compound 4, concentration for 50% growth inhibition: 56000 nM
Compound 4: middle estimate off by 2.7-fold (0.43 log units), on the high side; the range from low to high includes it.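

In this assay the change from 4-methoxyphenyl to 3,4-dimethoxyphenyl gives an at least 1.7-fold lower number from compound 3 to compound 4 (0.25 log units; that floor lies within the scatter), so this step is known only as a floor and does not by itself establish a real gain in growth inhibition. The step of the same kind on the core of compound 1 cannot be read, and so the two steps cannot be compared, because both of its ends sit at a limit: the limit of > 100000 nM in this assay, at which 3 of the 4 values shown sit. The data therefore do not show whether the change carries from one core to the other, and the two additions also sit at different places on the aromatic ring.

The compounds shown leave open how the 3,4-dimethoxyphenyl group would read on the core of compound 1. They also leave open whether an amine or a carboxylic acid, in place of the added methoxy of compound 4, would give a value clear of the limit by more than the usual scatter.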